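The source may report more compounds than this note shows. Statements on the series, on what has been measured and on what is new or still open speak of the compounds shown alone.

Measured so far in a functional assay on the whole organism for inhibition, with Mythimna separata as the target, with a stated time of 5 days; on this read-out higher numbers stand for an effect only at larger amounts of compound and lower numbers for an effect already at smaller amounts:
- compound 1 `CC(C)(C)n1ncc(OCc2nnc(-c3ccccc3Cl)o2)c(Cl)c1=O` gives 61.2 ug/mL
- compound 2 `CC(C)(C)n1ncc(OCc2nnc(-c3cccs3)o2)c(Cl)c1=O` gives > 300 ug/mL (a limit)
- compound 3 `CC(C)(C)n1ncc(OCc2nnc(-c3ccc(F)cc3)o2)c(Cl)c1=O` gives 5.2 ug/mL

Among the measured compounds shown here, compound 3 has the lowest number so far (5.2 ug/mL) and its steps to the other two lie beyond the scatter. Compound 4 `CC(C)(C)n1ncc(OCc2nnc(-c3ccccc3F)o2)c(Cl)c1=O` differs from it by one change (2-fluorophenyl in place of 4-fluorophenyl on an aromatic carbon) with 2-fluorophenyl in place of 4-fluorophenyl on an aromatic carbon. The closest measured step is a 12-fold lower number from compound 1 to compound 3 (1.07 log units; beyond the scatter) and it swaps 2-chlorophenyl for 4-fluorophenyl, so the halogen changes there as well. The step of an at least 57-fold lower number from compound 2 to compound 3 (1.76 log units; beyond the scatter) starts from a limit and concerns thiophen-2-yl, so it bears little here. A move to a higher number in this assay is therefore expected, smaller than the step from the 2-chlorophenyl compound. The expected step is a 3.8-fold higher number from compound 3 to compound 4 (0.59 log units; beyond the scatter) and it would lie modestly beyond the scatter. For compound 4 the estimate is 20 ug/mL with 6 ug/mL to 80 ug/mL as the expected range.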

Compound 4, half-maximal effective concentration: 16.8 ug/mL
Estimate against measurement, compound 4: 1.2-fold (0.08 log units) above, and the stated range covers the measured number.
By their numbers in this assay, from the lowest: compound 3; then compound 4; then compound 1. At a limit, above all of these: compound 2.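

In this assay, moving the halogen alone, 2-fluorophenyl in place of 4-fluorophenyl, gives a 3.2-fold higher number from compound 3 to compound 4 (0.51 log units; beyond the scatter), so the place of the fluoro on this phenyl counts even with the atoms unchanged. Fluoro in place of chloro alone gives a 3.6-fold lower number from compound 1 to compound 4 (0.56 log units; beyond the scatter), which separates the halogen swap from the change of place mixed in the earlier comparison of 2-chlorophenyl and 4-fluorophenyl. The step of an at least 17-fold lower number from compound 2 to compound 4 (1.25 log units; beyond the scatter) starts from a limit and so gives only a bound: the limit of > 300 ug/mL in this assay, at which 1 of the 4 values shown sits.

From the compounds shown here alone, whether chloro responds to a change of place as fluoro does remains open. Also open, going by these compounds, is how a methoxy or an amine on the phenyl would compare with either halogen.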